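Lengthening the amine chain on a pyrazolopyridine core

The source may report more compounds than this note shows. Statements on the series, on what has been measured and on what is new or still open speak of the compounds shown alone.

Measured so far in an assay on HEK293 cells for displacement of a labelled ligand from corticotropin-releasing factor receptor 1 (Homo sapiens); a lower number here means a stronger inhibitor, a higher number a weaker inhibitor:
Compound 1 `CCN(CC1CC1)c1cc(C)nc2c(-c3ccc(Cl)cc3Cl)nn(C)c12` gives 4.4 nM.
Compound 2 `CCCN(CC1CC1)c1cc(C)nc2c(-c3ccc(Cl)cc3Cl)nn(C)c12` gives 1.7 nM.
Compound 3 `CCCCCN(CCC)c1cc(C)nc2c(-c3ccc(Cl)cc3Cl)nn(C)c12` gives 1.2 nM.

All three compounds share one core and differ only in the two chains carried by the amino nitrogen attached to it. Compound 1 and compound 2 differ by methyl in place of hydrogen on a saturated chain carbon, two bonds along the chain from a nitrogen on an aromatic ring. That change gave a 2.6-fold lower number from compound 1 to compound 2 (0.41 log units; beyond the scatter). Compound 1 and compound 3 differ more broadly, by pentyl(propyl)amino in place of (cyclopropylmethyl)(ethyl)amino on an aromatic carbon, and that gave a 3.7-fold lower number from compound 1 to compound 3 (0.56 log units; beyond the scatter). Compound 2 and compound 3 differ by the ring in one chain being opened into a straight chain, and that gave a 1.4-fold lower number from compound 2 to compound 3 (0.15 log units; within the scatter), so the two cannot be ranked against each other.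

Compound 4 `CCCCCN(CCCC)c1cc(C)nc2c(-c3ccc(Cl)cc3Cl)nn(C)c12` has not yet been measured. It differs from compound 3 by methyl in place of hydrogen on a saturated chain carbon, three bonds along the chain from a nitrogen on an aromatic ring. This is the same kind of change as the step from compound 1 to compound 2, but not the same: there the methyl entered two bonds along the chain from the nitrogen on the aromatic ring, here it enters three bonds along that chain, and the two cores differ as told above. Because the earlier step of a 2.6-fold lower number from compound 1 to compound 2 (0.41 log units; beyond the scatter) was modest and the next lengthening, a 1.4-fold lower number from compound 2 to compound 3 (0.15 log units; within the scatter), stayed within the scatter, the step from compound 3 to compound 4 is expected to be small, about a 1.2-fold lower number from compound 3 to compound 4 (0.08 log units; within the scatter). Compound 4 is therefore estimated at 1 nM in this assay, with a likely range from 0.4 nM to 2.5 nM.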

Compound 4, inhibition constant: 0.9 nM
Estimate against measurement, compound 4: 1.1-fold (0.05 log units) above; measured number inside the range.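

In this assay, adding the methyl gave a 1.3-fold lower number from compound 3 to compound 4 (0.12 log units; within the scatter), so this lengthening of the chain produced no change that can be told apart from the ordinary spread of repeated measurements. Set beside the earlier step of the same kind, the new step cannot be separated from it, so the compounds shown give no sign that the size of this change depends on the rest of the molecule: the same change on two cores in this assay, a 2.6-fold lower number (0.41 log units; beyond the scatter) from compound 1 to compound 2 and a 1.3-fold lower number (0.12 log units; within the scatter) from compound 3 to compound 4, 1.9-fold (0.29 log units) apart, within the scatter of two such steps

Among the compounds shown here, this does not prove that the change carries over unaltered from one core to another, since only two steps are compared, the methyl enters two bonds along the chain in one and three bonds along in the other, and one of the two steps is itself too small to read as a real change.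

The compounds shown leave open how a longer chain such as hexyl, or a chain holding an ether oxygen such as methoxyethyl, would fare in this assay. They also leave open whether an amine or a carboxylic acid at the end of one chain would keep the number as low as in compound 3 and compound 4.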